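Methyl to 1-Hydroxyethyl: Expecting Only a Modest Shift

The compounds below may be only part of what the source reports. "The series", "measured", "known", "first", "only" and "open" are said of these compounds alone.

Compounds measured so far in a functional assay on the whole organism (Tail, strain ICR) with Mus musculus as the target, in the tail flick test, with a stated time of 90 min, at a dose of 25 umol/kg by the oral route; on this read-out lower numbers stand for a weaker effect and higher numbers for a stronger effect at the one dose given:
Compound 1, `C[C@H](NC(=O)CN(c1nc(Cl)nc2[nH]cnc12)C1CC1)C(=O)OCc1ccccc1`, gives 44.2%.
Compound 2, `O=C(CN(c1ncnc2c1ncn2C1CCCCO1)C1CC1)N[C@@H](CCC(=O)OCc1ccccc1)C(=O)OCc1ccccc1`, gives 25.2%.

Compound 1 stands highest of the two numbers measured; the nearest is compound 2, whose number is lower by a gap beyond the usual scatter. For the measured compounds named here, these two compounds differ in more than one place, so no single-change step between measured compounds exists to guide a forecast.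

Compound 3, `C[C@@H](O)[C@H](NC(=O)CN(c1nc(Cl)nc2[nH]cnc12)C1CC1)C(=O)OCc1ccccc1`, has not yet been measured. It differs from compound 1 by 1-hydroxyethyl in place of methyl on a saturated chain carbon bound to an amide-type nitrogen and a carbonyl carbon. Going by the values given here, no measured step of this kind is available, so the expected shift in this assay is placed near zero, within the usual scatter, with a wide range allowed in either direction. Compound 3 is therefore expected to give 40%, in a range from 20% to 60%. The step of a number 4.2 percentage points lower from compound 1 to compound 3 (within the scatter) that this estimate means is expected to be small.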

Compound 3, a percentage reported as activity, at one dose (the size of the read-out at that dose, not a potency): 29.9%
Beside the measured number, compound 3's estimate is 10.1 percentage points above it; measured number inside the range.
By their numbers in this assay, from the lowest: compounds 2 and 3 (each within the scatter of the next); then compound 1.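

For the compounds shown here, putting 1-hydroxyethyl in place of methyl on a saturated chain carbon bound to an amide-type nitrogen and a carbonyl carbon gives, in this assay, the first single-change comparison at this position: a number 14.3 percentage points lower from compound 1 to compound 3 (beyond the scatter). With the rest of the molecule unchanged, this shows that the read-out at this one dose is sensitive to what this position carries. Nothing available explains why the number falls when 1-hydroxyethyl enters.

The compounds shown leave open whether the added carbon or the added oxygen accounts for the step, a question that an ethyl group and a hydroxymethyl group at this position could help to separate. They also leave open how the other arrangement at the new stereocentre, or a carboxylic acid or an amine on this chain, would compare with methyl.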